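Replacing the fluorophenoxy group with fluorine

This account rests on a few compounds, and the source may have more. Where it says the series, first, only, none or still open, it means among the compounds named here.

For the measured compounds named here, compound 3 `C=CC(=O)NCc1coc(-c2c(N)ncnc2Nc2ccc(Oc3ccc(F)cc3)c(Cl)c2)n1` is one of three compounds measured in an in vitro ADME assay on microsomes from liver (Homo sapiens) for metabolic stability, tested at 5 uM; a lower number here means that the compound disappears faster, a higher number that the compound lasts longer. In this assay compound 3 reaches only a limit, > 1.66 h. Compound 2 `C=CC(=O)NCc1coc(-c2c(N)ncnc2Nc2ccc(Oc3ccccc3)c(Cl)c2)n1` likewise gives only a limit in this assay, > 1.66 h. Compound 1 `C=CC(=O)NCc1coc(-c2c(N)ncnc2Nc2ccc(OCc3ccccn3)c(F)c2)n1` gives 0.45 h in this assay. Going by the values given here, the one step measured between compounds that differ in a single place, a step that the two limits leave unreadable from compound 2 to compound 3, cannot be sized, because both values sit at the limit of > 1.66 h in this assay, at which 2 of the 3 values shown sit. Among the compounds with values here, compound 4 `C=CC(=O)NCc1coc(-c2c(N)ncnc2Nc2ccc(F)c(Cl)c2)n1` has not been measured; it differs from compound 3 in this way. fluoro in place of 4-fluorophenoxy on an aromatic carbon No measured step shares this change, and the single step that exists is unreadable, so the data give no size for it in either direction. Compound 3 itself sits at the limit of this assay, so the expected value for compound 4 is placed near that limit, estimated at 1.5 h, within 0.6 h to 3 h. The expected step of an at least 1.1-fold lower number from compound 3 to compound 4 (0.04 log units; that floor lies within the scatter) is therefore small, with no direction expected beyond the scatter.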

Compound 4, half-life: 0.267 h
Estimate against measurement, compound 4: 5.6-fold (0.75 log units) above, and the stated range ends above it.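

In this assay, the aromatic carbon ortho to a chloro group now gives readable steps, where the earlier pair offered none: fluoro in place of 4-fluorophenoxy gives an at least 6.2-fold lower number from compound 3 to compound 4 (0.79 log units; beyond the scatter), and fluoro in place of phenoxy gives an at least 6.2-fold lower number from compound 2 to compound 4 (0.79 log units; beyond the scatter). Both steps are floors rather than sizes, because compound 2 and compound 3 each rest on a limit: the limit of > 1.66 h in this assay, at which 2 of the 4 values shown sit.

The step between compound 2 and compound 3 still cannot be read, so any effect of the fluoro on the phenoxy ring stays hidden, while removing the whole aryl ether is clearly visible.

On these data alone, whether the ether oxygen or the aromatic ring carries the step remains open, and a methoxy group or an amine on this carbon would bear on that. Compound 1 differs from these compounds in more than one place, so it does not settle the question.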